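Anilinoacetyl hydrazone replaces hydroxybenzylidene on the shared core

The source may hold more compounds than are shown below. What is called first, only, known or untested is meant among the compounds shown, and "the series" means these compounds.

This account follows one change on a shared core. Compound 1 `O=C(N/N=C\c1cccc(O)c1)Nc1nnc(COc2ccc3ccccc3c2)o1` was tested in a functional assay on the whole organism (strain Swiss albino) with Mus musculus as the target, with a stated time of 4 h (a lower number here means that less compound is needed, a higher number that more compound is needed for the effect), where compound 1 gives 300 mg/kg. A second measured compound, compound 2 `C/C(=N/NC(=O)Nc1nnc(COc2ccc3ccccc3c2)o1)c1ccc([N+](=O)[O-])cc1`, gives in this assay a value of 300 mg/kg, so compound 1 stands level with compound 2 at the digits reported, within the scatter of the method. Among the compounds with values here, no step between two measured compounds that differ in one place is available, so the two values only show that both lie at the same dose.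

Compound 3 `C/C(=N/NC(=O)Nc1nnc(COc2ccc3ccccc3c2)o1)c1ccc(N)cc1` has not yet been measured in this assay. It differs from compound 1 by a group of 10 heavy atoms (8 carbon, 2 nitrogen; one six-membered aromatic ring of carbon only) in place of a group of 9 heavy atoms (7 carbon, 1 nitrogen, 1 oxygen; one six-membered aromatic ring of carbon only), on an amide-type nitrogen. Because compound 1 gives 300 mg/kg and compound 2 gives 300 mg/kg, the step is expected to be none beyond the scatter, and the expected step of no change at the digits printed from compound 1 to compound 3 (within the scatter) is therefore small. The minimum effective dose of compound 3 is estimated at 300 mg/kg, within a range of 100 mg/kg to 600 mg/kg.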

Compound 3, minimum effective dose: 300 mg/kg
Beside the measured number, compound 3's estimate shows no gap at the digits printed; measured number inside the range.
By their numbers in this assay, from the lowest: compounds 1, 2 and 3 (each within the scatter of the next).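

In this assay the exchange of groups on the amide-type nitrogen gives no change at the digits printed from compound 1 to compound 3 (within the scatter) and amino in place of nitro on an aromatic carbon gives no change at the digits printed from compound 2 to compound 3 (within the scatter) as well. Within the data shown here, these are the first steps between compounds that differ in one place, and neither separates the compounds beyond the scatter, whereas the earlier pair offered only two matching values with no such step. No measurement here offers an explanation for this result.

All three compounds stand level, and they do not show whether any group at this place can shift the minimum effective dose. Going by these compounds, whether a carboxylic acid or a longer chain in place of the amino group would give a different dose remains open.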